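Butyl to ethyl on an acetylated nucleoside isoxazole

The source may report more compounds than this note shows. Statements on the series, on what has been measured and on what is new or still open speak of the compounds shown alone.

Measured so far in a functional assay on NCI-H23 cells (Homo sapiens) for cytotoxicity, read by sulforhodamine B assay, tested at 10 uM; a lower number here means less inhibition, a higher number more inhibition at the concentration tested (going by the name of the read-out):
- compound 1 `CC(C)(C)c1ccc(Cn2cc(-c3cn([C@H]4C[C@H](O)[C@@H](CO)O4)c(=O)[nH]c3=O)nn2)cc1`: 95%
- compound 2 `CCCCc1ccc(-c2cc(-c3cn([C@H]4C[C@H](OC(C)=O)[C@@H](COC(C)=O)O4)c(=O)[nH]c3=O)on2)cc1`: 97.4%
- compound 3 `CC(=O)OC[C@H]1O[C@@H](n2cc(-c3cn(Cc4ccc(C(C)(C)C)cc4)nn3)c(=O)[nH]c2=O)C[C@@H]1OC(C)=O`: 106%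

The three measured compounds give numbers that lie within the usual scatter of one another, so none of them can be set apart from the others. Compound 2 gives 97.4%; its nearest neighbour is compound 1, and its furthest is compound 3, and both gaps fall within the scatter. For the measured compounds named here, compound 1 and compound 3 share a triazole-linked core, whereas compound 2 carries the isoxazole-linked core with a 4-butylphenyl group; no step between measured compounds that differ in only one place is available.

The unmeasured compound 4 `CCc1ccc(-c2cc(-c3cn([C@H]4C[C@H](OC(C)=O)[C@@H](COC(C)=O)O4)c(=O)[nH]c3=O)on2)cc1` differs from compound 2 in one place: hydrogen in place of ethyl on a saturated chain carbon, two bonds along the chain from an aromatic carbon. Cut one bond further out, the change reads butyl to ethyl on the phenyl ring. Because compound 2 gives 97.4%, near the top of the range this read-out can report, there is little room upward, and the account expects a step from compound 2 to compound 4 in this assay of a number 5.4 percentage points lower from compound 2 to compound 4 (within the scatter), that is, none beyond the scatter or a modest fall. For compound 4 the estimate is 92%, with a range from 70% to 105%.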

Compound 4, a percentage reported as inhibition, at one concentration (the size of the read-out at that concentration, not a potency): 92.7%
The estimate for compound 4 lay 0.7 percentage points below the measured number, and the stated range covers the measured number.
By their numbers in this assay, from the lowest: compounds 4, 1, 2 and 3 (each within the scatter of the next, the first and the last beyond it).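

For the compounds shown here, the change from 4-butylphenyl to 4-ethylphenyl gives the first comparison in this assay between compounds that differ in one place, a number 4.7 percentage points lower from compound 2 to compound 4 (within the scatter). The earlier compounds shown here could not show this, as they offered no such pair; this one shows that, on this core and at this position, the butyl and ethyl chains cannot be told apart by this read-out. Both numbers come from a single concentration and say nothing of potency, so the two compounds could still differ at lower concentrations, and no measurement shown here offers an explanation for the result.

Only these two chain lengths are shown at this position, so it remains open whether a methyl group, a longer chain such as hexyl, or a chain ending in an amine or a carboxylic acid would stay within the scatter of compound 2 in this assay. Also open, as far as these compounds go, is whether the 4-ethylphenyl group would give a comparable number with free hydroxyl groups in place of the acetates on the sugar.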